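Working notes: expected cytotoxicity of compound 4 in the series

This account rests on a few compounds, and the source may have more. Where it says the series, first, only, none or still open, it means among the compounds named here.

Measured so far in an ADME assay on J774 cells (Mus musculus, strain BALB/c) for cytotoxicity, read by resazurin assay, with a stated time of 72 h; on this read-out higher numbers stand for lower toxicity in this test and lower numbers for higher toxicity in this test:
Compound 1 `CC(/C=N/Nc1ccc([N+](=O)[O-])cc1)=N\NC(=O)c1ccccc1` gives > 100000 nM, a limit of the assay.
Compound 2 `CC(/C=N/Nc1ccc([N+](=O)[O-])cc1)=N\NC(=O)c1ccc(N)cc1` gives 75000 nM.
Compound 3 `COc1cc(C(=O)N/N=C(C)/C=N/Nc2ccc([N+](=O)[O-])cc2)ccc1O` gives > 100000 nM, a limit of the assay.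

Compound 3 stands at the limit of > 100000 nM in this assay, at which 2 of the 3 values shown sit, so only a limit is known for it. Compound 4 `CC(/C=N/Nc1ccc([N+](=O)[O-])cc1)=N\NC(=O)c1ccc(Cl)cc1` differs from it by 4-chlorophenyl in place of 4-hydroxy-3-methoxyphenyl on a carbonyl carbon. Among the measured compounds shown here, two measured steps bear on changes at the same carbonyl carbon: a step that the two limits leave unreadable from compound 1 to compound 3, and an at least 1.3-fold higher number from compound 2 to compound 3 (0.12 log units; that floor lies within the scatter), whose floor is within the scatter. The remaining step, an at least 1.3-fold lower number from compound 1 to compound 2 (0.12 log units; that floor lies within the scatter), also has its floor within the scatter. No step beyond the scatter is therefore expected in this assay. Compound 4 is expected to give 100000 nM, with a range from 50000 nM to 200000 nM, quite possibly reported again only as a limit. The expected step is a number no higher from compound 3 to compound 4 (the limit leaves the size open), within the scatter.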

Compound 4, half-maximal cytotoxic concentration: 63900 nM
Beside the measured number, compound 4's estimate is 1.6-fold (0.19 log units) above it; low and high end bracket the measured number.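

In this assay, chloro in place of amino on an aromatic carbon gives a 1.2-fold lower number from compound 2 to compound 4 (0.07 log units; within the scatter), so the two groups are not told apart here. Chloro in place of hydrogen gives an at least 1.5-fold lower number from compound 1 to compound 4 (0.19 log units; that floor lies within the scatter), and 4-chlorophenyl in place of 4-hydroxy-3-methoxyphenyl gives an at least 1.5-fold lower number from compound 3 to compound 4 (0.19 log units; that floor lies within the scatter); neither floor lies beyond the scatter. Amino is thus no longer the only group here with a measured value, but both floors leave the true size open because they rest on a limit: the limit of > 100000 nM in this assay, at which 2 of the 4 values shown sit.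

As far as these compounds go, whether a carboxylic acid or a dimethylamino group on that aromatic carbon would give a step beyond the scatter remains open.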